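This account rests on a few compounds, and the source may have more. Where it says the series, first, only, none or still open, it means among the compounds named here.

Working notes on the series in a functional assay on HL-60 cells (Homo sapiens) for cytotoxicity, read by WST assay, with a stated time of 48 h; on this read-out lower numbers stand for stronger inhibition and higher numbers for weaker inhibition.

Compound 1 `CC(C)C[C@]1(O)NC(=O)[C@]2(OC(Cc3ccccc3)=CC2=O)[C@H]1O` gives 28000 nM in this assay. Compound 2 `CC(C)CC(=O)[C@@H]1O[C@@]12C(=O)C=C(Cc1ccccc1)NC2=O` gives 37300 nM in this assay, and the numbers of compound 1 and compound 2 lie within the scatter of each other. The difference between the two cores is not broken down here. Compound 3 `CC1=CC(=O)[C@@]2(O[C@H]2C(=O)CC(C)C)C(=O)N1` gives 1600 nM in this assay. Compound 3 arises from compound 2 by hydrogen in place of phenyl on a saturated chain carbon bound to a double-bonded ring carbon, and that single change made a 23-fold lower number from compound 2 to compound 3 (1.37 log units; beyond the scatter), a large step for one substituent.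

Compound 4 `CC1=CC(=O)[C@]2(O1)C(=O)N[C@@](O)(CC(C)C)[C@@H]2O` is not yet measured in this assay. It arises from compound 1 by hydrogen in place of phenyl on a saturated chain carbon bound to a double-bonded ring carbon, the same change at the same place as the one from compound 2 to compound 3; the change therefore occurs twice among the compounds shown, once measured and once open. The cores of compound 1 and compound 2 are not the same, and how far the step carries over is the open question.

Compound 4 is expected to stand a 19-fold lower number from compound 1 to compound 4 (1.27 log units; beyond the scatter) from compound 1 in this assay, because the same change made a 23-fold lower number from compound 2 to compound 3 (1.37 log units; beyond the scatter) on the neighbouring core, with the range widened for the difference in core. For compound 4 the estimated number in this assay is 1500 nM, expected to fall between 300 nM and 8000 nM.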

Compound 4, half-maximal inhibitory concentration: > 50000 nM
Compound 4 gave a limit, no number; the forecaster's own chance of this, stated with the estimate: 5%; at least 33-fold (1.52 log units) between middle value and limit.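

In this assay compound 4 gives > 50000 nM, which is a limit of the assay and not a number. With benzyl going to methyl on the core of compound 1, the step reads an at least 1.7-fold higher number from compound 1 to compound 4 (0.25 log units; that floor lies within the scatter), and the change does not carry over from the core of compound 2 to the core of compound 1 with the size and direction it had there: the same change on two cores in this assay, a 23-fold lower number (1.37 log units; beyond the scatter) from compound 2 to compound 3 and an at least 1.7-fold higher number (0.25 log units; that floor lies within the scatter) from compound 1 to compound 4, at least 41-fold (1.61 log units) apart, beyond the scatter of two such steps. This shows that the large step seen on one core cannot be transferred to the other in this series, but it does not fix the size of the step on the core of compound 1, does not place compound 4 beyond the scatter of compound 1, and rests on a single pair per core, so it does not say which part of the cores makes the difference.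

The compounds shown leave open whether the two cores also part ways for other groups at this place, such as an ethyl group, a longer chain or an amine on a saturated chain carbon bound to a double-bonded ring carbon. They also leave open how the core of compound 1 behaves with any such group that gives a reading inside the range of the assay rather than a limit.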